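The source may hold more compounds than are shown below. What is called first, only, known or untested is meant among the compounds shown, and "the series" means these compounds.

Working notes on the series. Among the measured compounds shown here, in a functional assay on MCF7 cells (Homo sapiens) for cytotoxicity, read by MTT assay, with a stated time of 72 h (on this read-out lower numbers stand for stronger inhibition and higher numbers for weaker inhibition), compound 1 `CCCCCCCCNc1nc(SCc2ccc(C(F)(F)F)cc2)nc2ccccc12` gives 26100 nM, the only outright number in the set. Compound 2 `FC(F)(F)c1ccc(CSc2nc(Nc3ccccc3Cl)c3ccccc3n2)cc1` reaches only the limit > 50000 nM in this assay. Compound 3 `Cc1ccc(Nc2nc(SCc3ccc(C(F)(F)F)cc3)nc3ccccc23)cc1` likewise ends at the limit > 50000 nM. Both aryl replacements of the octyl chain read as an at least 1.9-fold higher number from compound 1 to compound 2 (0.28 log units; that floor lies within the scatter) and an at least 1.9-fold higher number from compound 1 to compound 3 (0.28 log units; that floor lies within the scatter), so the evidence on these steps is the limit of > 50000 nM in this assay, at which 2 of the 3 values shown sit. Compound 4 `COc1ccc(Nc2nc(SCc3ccc(C(F)(F)F)cc3)nc3ccccc23)cc1OC` is not yet measured; it differs from compound 1 by 3,4-dimethoxyphenyl in place of octyl on a nitrogen on an aromatic ring. The two aryl steps from compound 1 both point upward in this assay, so compound 4 is expected to follow them, estimated at 55000 nM, a change of a 2.1-fold higher number from compound 1 to compound 4 (0.32 log units; beyond the scatter), with the range 22000 nM to 150000 nM, most likely again at the limit.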

Compound 4, half-maximal inhibitory concentration: > 50000 nM
Compound 4: only a limit was reported (the forecaster's own chance of this, stated with the estimate: 70%); the middle value does not contradict the limit.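

In this assay, 3,4-dimethoxyphenyl in place of octyl on the nitrogen gives an at least 1.9-fold higher number from compound 1 to compound 4 (0.28 log units; that floor lies within the scatter), so the methoxy-bearing aryl group also yields no outright number, like the 2-chlorophenyl and 4-methylphenyl groups. The steps among compound 2, compound 3 and compound 4 cannot be read, as each of these compounds ends at a limit. The evidence at this position is therefore a limit and not a ranking: the limit of > 50000 nM in this assay, at which 3 of the 4 values shown sit.

From the compounds shown here alone, whether a butyl chain, a benzyl group or a cyclohexyl group on this nitrogen gives an outright number stays open. So does the effect of a dodecyl chain compared with octyl.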